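The source may hold more compounds than are shown below. What is called first, only, known or untested is meant among the compounds shown, and "the series" means these compounds.

Compound 1 `CC(C)(C)n1cc2c(n1)C(=O)CC1(CCN(C(=O)c3cc(-c4ccc(Br)cc4)nc4ccccc34)CC1)O2`: 820 nM
Compound 2 `CN(C)c1ccc(-c2cc(C(=O)N3CCC4(CC3)CC(=O)c3nn(C(C)(C)C)cc3O4)c3ccccc3n2)cc1`: 1730 nM
Compound 3 `CC(C)(C)n1cc2c(n1)C(=O)CC1(CCN(C(=O)c3cc(-c4ccccn4)nc4ccccc34)CC1)O2`: 1500 nM

In a functional assay on HepG2 cells (Homo sapiens) for inhibition, read by MTT assay, with a stated time of 72 h (on this read-out higher numbers stand for weaker inhibition and lower numbers for stronger inhibition), compound 1 gives 820 nM, the lowest of the three numbers. Compound 3, the nearest to it, lies within the scatter, as the step of a 1.8-fold higher number from compound 1 to compound 3 (0.26 log units; within the scatter) shows, while the step of a 2.1-fold higher number from compound 1 to compound 2 (0.32 log units; beyond the scatter) puts compound 2 beyond it.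

Compound 4 `Cc1cc(C(=O)N2CCC3(CC2)CC(=O)c2nn(C(C)(C)C)cc2O3)c2ccccc2n1` is the compound not yet measured. It differs from compound 1 in one place: methyl in place of 4-bromophenyl on an aromatic carbon

Two of the measured steps bear on this change, both of which alter the same position on the shared core. The step of a 1.8-fold higher number from compound 1 to compound 3 (0.26 log units; within the scatter) exchanges the whole 4-bromophenyl and stays within the scatter; the step of a 2.1-fold higher number from compound 1 to compound 2 (0.32 log units; beyond the scatter) alters only its substituent and is modest. Neither replaces the aryl group with a methyl, so the step to compound 4 is a larger change than either. On this basis compound 4 is expected to show a higher number, with the step of a 3.0-fold higher number from compound 1 to compound 4 (0.48 log units; beyond the scatter) as the estimate. In this assay compound 4 is therefore estimated at 2500 nM, within a range from 800 nM to 8000 nM.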

Compound 4, half-maximal inhibitory concentration: 9480 nM
Compound 4: the middle estimate sits 3.8-fold (0.58 log units) below what was measured; measured number above the stated range.
By their numbers in this assay, from the lowest: compounds 1, 3 and 2 (each within the scatter of the next, the first and the last beyond it); then compound 4.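

In this assay this position proves far more sensitive to losing the ring than to changing it: a 12-fold higher number from compound 1 to compound 4 (1.06 log units; beyond the scatter) is a large step, well beyond those seen among the three ring-bearing compounds. The pattern holds for all three groups, with a 6.3-fold higher number from compound 3 to compound 4 (0.80 log units; beyond the scatter) and a 5.5-fold higher number from compound 2 to compound 4 (0.74 log units; beyond the scatter) also pointing upward, so 4-bromophenyl, pyridin-2-yl and 4-(dimethylamino)phenyl each give a lower number than methyl. No measurement at hand explains this rise.

The compounds shown leave open whether a cyclohexyl ring or a longer alkyl chain on this carbon would fall closer to the aryl compounds or to compound 4. From the compounds shown here alone, how an amine at the same place would compare also remains open.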